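This account rests on a few compounds, and the source may have more. Where it says the series, first, only, none or still open, it means among the compounds named here.

Measured in a functional assay on A549 cells (Homo sapiens) for antiproliferative activity, read by MTT assay; a lower number here means a stronger inhibitor, a higher number a weaker inhibitor:
Compound 1 `Cn1c(=O)c(=O)n(C2CCCC2)c2nc(N/N=C/c3ccccc3)ncc21`: > 100000 nM, a limit.
Compound 2 `Cn1c(=O)c(=O)n(C2CCCC2)c2nc(N/N=C/c3cc(C(F)(F)F)c(O)c(C(F)(F)F)c3)ncc21`: 22900 nM.
Compound 3 `Cn1c(=O)c(=O)n(C2CCCC2)c2nc(N/N=C/c3cccs3)ncc21`: > 100000 nM, a limit.

Compound 2 alone carries an actual number, 22900 nM. The other two compounds sit at the limit of > 100000 nM in this assay, at which 2 of the 3 values shown sit.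

Compound 4 `Cn1c(=O)c(=O)n(C2CCCC2)c2nc(N/N=C/c3cc(C(F)(F)F)cc(C(F)(F)F)c3)ncc21` differs from compound 2 by one change, hydrogen in place of hydroxy on an aromatic carbon. For the measured compounds named here, the only measured step, a step that the two limits leave unreadable from compound 1 to compound 3, lies at another place and has no readable size, so it does not bear on this change. Going by the values given here, compound 2, at 22900 nM, is the only compound with hydroxy and the only one with a number, so a step toward weaker values is expected in this assay, though this is weakly supported. The estimated step is a 1.7-fold higher number from compound 2 to compound 4 (0.24 log units; within the scatter). For compound 4 the estimated value is 40000 nM, with an expected range of 15000 nM to 100000 nM.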

Compound 4, half-maximal inhibitory concentration: 3230 nM
For compound 4 the middle estimate is 12-fold (1.09 log units) above the measured one, outside the stated range (below it).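

In this assay, hydrogen in place of hydroxy gives a 7.1-fold lower number from compound 2 to compound 4 (0.85 log units; beyond the scatter). So at this position, ortho to two trifluoromethyl groups and para to a large group, hydroxy is not required for a numeric value in this series, and its removal moves the value toward stronger inhibition. The earlier compounds gave no readable step at this place, and the one step among them cannot be read: the limit of > 100000 nM in this assay, at which 2 of the 4 values shown sit.

Still open, going by these compounds, is how a methoxy group, an amine or a fluorine atom at this position would compare with hydrogen and hydroxy. Also open, on these data alone, is what a single trifluoromethyl group would give with hydrogen at this position.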